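The source may hold more compounds than are shown below. What is called first, only, known or untested is meant among the compounds shown, and "the series" means these compounds.

Compound 1 `Cc1cc(C)c(Oc2cc(Nc3ccc(C#N)cc3)ncc2C(=O)NCc2cn(Cc3cccc([N+](=O)[O-])c3)nn2)c(C)c1`: >= 156000 nM in an ADME assay on MT4 cells (Homo sapiens) for cytotoxicity, read by MTT assay, with a stated time of 5 days (a higher number here means that more compound is tolerated, a lower number that less compound is tolerated), a limit of the assay.
Compound 2 `CC(=O)Cn1cc(CNC(=O)c2cnc(Nc3ccc(C#N)cc3)cc2Oc2c(C)cc(C)cc2C)nn1`: 19400 nM.
Compound 3 `CCOC(=O)CCn1cc(CNC(=O)c2cnc(Nc3ccc(C#N)cc3)cc2Oc2c(C)cc(C)cc2C)nn1`: 21500 nM.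

Compound 3 gives the highest of the two plain numbers shown, with compound 2 nearest, and the step of a 1.1-fold higher number from compound 2 to compound 3 (0.04 log units; within the scatter) lies within the scatter. Compound 4 `Cc1cc(C)c(Oc2cc(Nc3ccc(C#N)cc3)ncc2C(=O)NCc2cn(Cc3ccc([N+](=O)[O-])cc3)nn2)c(C)c1` differs from compound 3 by 4-nitrophenyl in place of (ethoxycarbonyl)methyl on a saturated chain carbon bound to an aromatic nitrogen. The measured steps that bear on this are an at least 7.2-fold lower number from compound 1 to compound 3 (0.86 log units; beyond the scatter) and an at least 8.0-fold lower number from compound 1 to compound 2 (0.90 log units; beyond the scatter), both beyond the scatter and both running from 3-nitrophenyl toward acetyl or (ethoxycarbonyl)methyl. Running the other way, toward 4-nitrophenyl, compound 4 is therefore expected to give a clearly higher number than compound 3, quite possibly only a limit again, as the limit of >= 156000 nM in this assay, at which 1 of the 3 values shown sits, shows. The estimate for compound 4 is 120000 nM, between 40000 nM and 300000 nM, so that a step of a 5.6-fold higher number from compound 3 to compound 4 (0.75 log units; beyond the scatter) is expected.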

Compound 4, half-maximal cytotoxic concentration: >= 139000 nM
Compound 4: a limit, no number (the forecaster's own chance of this, stated with the estimate: 55%); middle value at least 1.1-fold (0.06 log units) away from the limit.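

In this assay compound 4 gives only a limit of the assay, >= 139000 nM. Placing 4-nitrophenyl on a saturated chain carbon bound to an aromatic nitrogen gives an at least 6.4-fold higher number from compound 3 to compound 4 (0.81 log units; beyond the scatter) and an at least 7.1-fold higher number from compound 2 to compound 4 (0.85 log units; beyond the scatter), so the gap first seen with 3-nitrophenyl recurs with a second nitrophenyl group. The step from compound 1 to compound 4 cannot be read, since both values are limits.

The compounds shown leave open whether these higher numbers go with the benzene ring or with the nitro group. A plain benzyl or a 4-aminobenzyl group at this place would separate the two.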